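The source may report more compounds than this note shows. Statements on the series, on what has been measured and on what is new or still open speak of the compounds shown alone.

Compound 2, `Cc1ccc(-c2c3c(nc(C)c2C(OC(C)(C)C)C(=O)O)CCN(C)C3)cc1`, has been tested in an ADME assay on MT2 cells (Homo sapiens) for cytotoxicity, read by XTT assay, with a stated time of 4 days (on this read-out lower numbers stand for higher toxicity in this test and higher numbers for lower toxicity in this test), and for compound 2 the result is only a limit, > 40000 nM. For the measured compounds named here, the one other measured compound, compound 1, `Cc1ccc(-c2c3c(nc(C)c2C(OC(C)(C)C)C(=O)O)CCN(Cc2ccccc2-c2ccccc2)C3)cc1`, differs from it by carrying 2-phenylphenyl where compound 2 carries hydrogen on a saturated chain carbon bound to an amine nitrogen in a ring. In this assay compound 1 likewise gives only a limit, > 40000 nM. Going by the values given here, the step that the two limits leave unreadable from compound 1 to compound 2 is therefore not readable because the limit of > 40000 nM in this assay, at which 2 of the 2 values shown sit, holds both of its ends; it tells only that neither compound showed toxicity within the tested range. Compound 3, `COC(=O)N1CCc2nc(C)c(C(OC(C)(C)C)C(=O)O)c(-c3ccc(C)cc3)c2C1`, is the next member of the series; the change from compound 2 is methoxycarbonyl in place of methyl on an amine nitrogen in a ring. Among the compounds with values here, no measured step speaks to this change, and the two values that exist both sit at the limit of the measurement. The step that the limit leaves unreadable from compound 2 to compound 3 is thus expected to be none beyond the scatter, with compound 3 most likely returning a limit again. For compound 3 the estimated value in this assay is 60000 nM, within a range from 30000 nM to 150000 nM.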

Compound 3, half-maximal cytotoxic concentration: > 40000 nM
Compound 3 ended at the assay's limit; the forecaster's own chance of this, stated with the estimate: 85%; the middle value does not contradict the limit.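

The step from compound 2 to compound 3, methoxycarbonyl in place of methyl, cannot be read, because both compounds rest on the same limit of the measurement: the limit of > 40000 nM in this assay, at which 3 of the 3 values shown sit.

The compounds shown leave open how toxic any of the three is to these cells, and whether changing the group on the ring's amine nitrogen alters that toxicity at all.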